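The source may hold more compounds than are shown below. What is called first, only, known or untested is meant among the compounds shown, and "the series" means these compounds.

Of the compounds shown here, two with a shared core have been measured for their ability to slow the growth of a human colon cancer cell line. Compound 1, with structure `CCN(CC)CCNC(=O)Nc1nc2ccc(-c3cnc(OC)c(NS(=O)(=O)c4ccc(C)cc4)c3)cc2s1`, gives 180 nM in a functional assay on HCT-116 cells (Homo sapiens) for antiproliferative activity, read by MTT assay, with a stated time of 72 h; a lower number here means a stronger inhibitor, a higher number a weaker inhibitor. Compound 2, with structure `CCCNc1nc2ccc(-c3cnc(Cl)c(NS(=O)(=O)c4ccc(F)cc4)c3)cc2s1`, is a different case: in this assay compound 2 reaches only a limit of the measurement, > 20000 nM, so its true value is not known, only that it lies beyond what the assay can register. This is the limit of > 20000 nM in this assay, at which 1 of the 2 values shown sits.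

Compound 3, with structure `O=S(=O)(Nc1cc(-c2ccc3nc(NC4CC4)sc3c2)cnc1Cl)c1ccc(F)cc1`, is not yet measured. It differs from compound 2 in one place: cyclopropyl in place of propyl on a nitrogen on an aromatic ring. The swap of a three-carbon chain for a three-carbon ring of the same size is a small one, and the expected step of a number no higher from compound 2 to compound 3 (the limit leaves the size open) is no larger than the ordinary scatter. Compound 3 is therefore expected to sit at about 20000 nM, most likely between 5000 nM and 60000 nM, and quite possibly again only as a limit.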

Compound 3, half-maximal inhibitory concentration: 5750 nM
Compound 3: the middle estimate sits 3.5-fold (0.54 log units) above what was measured, and the stated range covers the measured number.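

Replacing propyl with cyclopropyl on a nitrogen on an aromatic ring gives an at least 3.4-fold lower number from compound 2 to compound 3 (0.54 log units; beyond the scatter) in this assay. This shows that the position responds even to a swap between a chain and a ring of the same carbon count, and that compound 3, at 5750 nM, gives a real number on this pair's shared core. Compound 2 stands at a limit, so the step is only a minimum and its true size remains unknown: the limit of > 20000 nM in this assay, at which 1 of the 3 values shown sits.

The compounds shown do not tell whether the ring itself matters or whether a cyclobutyl ring, a longer chain such as pentyl, or a plain amino group would lower the number further. They also leave open whether the same swap would have a similar effect when the other groups on the shared core differ.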